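Dithiocarbamate triazoles: a free piperazine with a methylphenyl cap

The source may hold more compounds than are shown below. What is called first, only, known or untested is meant among the compounds shown, and "the series" means these compounds.

The compounds here share one core, a triazole carrying a dithiocarbamate linked to a piperazine, and differ in the group on the saturated chain carbon bound to the aromatic nitrogen and in whether the piperazine is free or capped. Compound 1 `Fc1ccc(Cn2cc(CSC(=S)N3CCNCC3)nn2)cc1` carries a 4-fluorophenyl group on a free piperazine. In a functional assay on PC-3 cells (Homo sapiens) for inhibition, read by MTT assay, with a stated time of 72 h (on this read-out lower numbers stand for stronger inhibition and higher numbers for weaker inhibition), compound 1 reaches only the limit of the test, > 128000 nM. Compound 2 `Cc1ccc(Cn2cc(CSC(=S)N3CCN(C(=O)OCc4ccccc4)CC3)nn2)cc1` carries a 4-methylphenyl group with a capped piperazine. In this assay compound 2 likewise reaches only the limit, > 128000 nM. Compound 3 `S=C(SCc1cn(Cc2ccc(Cl)c(Cl)c2)nn1)N1CCNCC1` carries a 3,4-dichlorophenyl group on a free piperazine; for compound 3 this assay reports "not determined" (no result reported), so it stands at no number at all, while the two values around it sit at the limit of > 128000 nM in this assay, at which 2 of the 3 values shown sit. Compound 4 `Cc1ccc(Cn2cc(CSC(=S)N3CCNCC3)nn2)cc1` is the next member, with a 4-methylphenyl group on a free piperazine. The change 4-methylphenyl in place of 3,4-dichlorophenyl on a saturated chain carbon bound to an aromatic nitrogen is a swap of the aromatic cap only. For the measured compounds named here, with no measured step to lean on, and both neighbours sitting at the limit, the expectation is that compound 4 will also fail to give a number within the range of this assay. Compound 4 is estimated at 150000 nM, with a range from 60000 nM to 400000 nM.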

Compound 4, half-maximal inhibitory concentration: 19800 nM
Compound 4: middle estimate off by 7.6-fold (0.88 log units), on the high side; measured number outside the range, below it.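

In this assay, for the compounds shown here, the free piperazine paired with the 4-methylphenyl group is the first combination here to give a real number, which shows that this series can register in the test rather than sitting only at its limit. With the 4-methylphenyl group held constant, hydrogen in place of benzyloxycarbonyl on an amine nitrogen in a ring gives an at least 6.4-fold lower number from compound 2 to compound 4 (0.81 log units; beyond the scatter), so the cap on the piperazine matters in this pair. With the piperazine kept free, methyl in place of fluoro on an aromatic carbon gives an at least 6.4-fold lower number from compound 1 to compound 4 (0.81 log units; beyond the scatter), so a single swap on the aromatic ring also matters, and both steps are minimum sizes, each starting from a limit rather than a number: the limit of > 128000 nM in this assay, at which 2 of the 4 values shown sit.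

From the compounds shown here alone, the change from 3,4-dichlorophenyl to 4-methylphenyl cannot be read: compound 3 has no number to compare, and the effect of the two chlorine atoms stays unknown. Also open, going by these compounds, is whether a smaller cap on the piperazine, such as an acetyl group, or an ethyl group in place of the methyl would hold a measurable number or return to the limit.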